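Swapping a Chloro for a Methyl on the Ester Ring

This account rests on a few compounds, and the source may have more. Where it says the series, first, only, none or still open, it means among the compounds named here.

Three esters of a shared core have been measured in an assay on isolated protein for antagonist activity at Bile acid receptor (Homo sapiens), read by HTRF, with a stated time of 30 min; on this read-out higher numbers stand for weaker inhibition and lower numbers for stronger inhibition. Compound 3, `CC(C)(C)c1cc(OC(=O)c2ccc(Cl)cc2)ccc1O`, carries a 4-chlorophenyl group on its carbonyl carbon. In this assay compound 3 gives > 100000 nM, which is a limit of the assay rather than a number. Compound 2, `Cc1ccc(C(=O)Oc2ccc(O)c(C(C)(C)C)c2)cc1`, carries a 4-methylphenyl group instead; in this assay compound 2 gives > 100000 nM, again a limit. Compound 1, `CC(C)(C)c1cc(OC(=O)c2ccc(Cl)cc2Cl)ccc1O`, has two chloro groups on that ring, and in this assay compound 1 gives 10200 nM. So compound 3 sits at the limit of > 100000 nM in this assay, at which 2 of the 3 values shown sit, alongside compound 2, while compound 1 is the only one with a readable number.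

The step of an at least 9.8-fold higher number from compound 1 to compound 3 (0.99 log units; beyond the scatter) shows that taking away one chloro moved the number out of the measurable range. The step that the two limits leave unreadable from compound 2 to compound 3 cannot be sized, since both ends are limits.

Compound 4, `Cc1ccccc1C(=O)Oc1ccc(O)c(C(C)(C)C)c1`, differs from compound 3 by 2-methylphenyl in place of 4-chlorophenyl on a carbonyl carbon. The two measured steps offer little guidance: one is a lower bound, the other unreadable, and neither tests a 2-methylphenyl group. Compound 4 is therefore expected to stay near the limit, with an estimated 90000 nM in this assay, ranging from 25000 nM to 300000 nM. That estimate means a step of an at least 1.1-fold lower number from compound 3 to compound 4 (0.04 log units; that floor lies within the scatter), most likely not beyond the scatter.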

Compound 4, half-maximal inhibitory concentration: > 100000 nM
Compound 4 gave a limit, no number; the forecaster's own chance of this, stated with the estimate: 60%; middle value at least 1.1-fold (0.04 log units) away from the limit.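

In this assay compound 4 gives > 100000 nM, which is a limit of the assay and not a number. Compound 2 and compound 3 also stand at a limit, and the steps from compound 4 to either one cannot be read. The compounds shown leave open whether 2-methylphenyl, 4-methylphenyl and 4-chlorophenyl differ at all on this read-out.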